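Bridged amine replacing piperidine on the quinoline-like core

The compounds below may be only part of what the source reports. "The series", "measured", "known", "first", "only" and "open" are said of these compounds alone.

Compound 2 `O=C(CCc1ccc(C(F)(F)F)cc1)Nc1ccc2nc(N3CCCCC3)ccc2c1` and compound 1 `CC(C)N(C)c1ccc2cc(NC(=O)CCc3ccc(C(F)(F)F)cc3)ccc2n1` share a core that differs only in the amine attached next to the ring nitrogen. In a functional assay on HEK293 cells for activation of melanin-concentrating hormone receptor 1 (Rattus norvegicus), read by inositol phosphate accumulation (on this read-out lower numbers stand for an effect already at smaller amounts and higher numbers for an effect only at larger amounts of compound), compound 2 gives 110 nM, the lowest of the two numbers at hand, and compound 1 gives 140 nM. For the measured compounds named here, the only measured step, a 1.3-fold lower number from compound 1 to compound 2 (0.10 log units; within the scatter), shows that exchanging the acyclic isopropyl(methyl)amino for piperidin-1-yl on this aromatic carbon left the read-out within the scatter.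

Compound 3 `O=C(CCc1ccc(C(F)(F)F)cc1)Nc1ccc2nc(N3CC4CCC3C4)ccc2c1` continues at the same position: a group of 7 heavy atoms (6 carbon, 1 nitrogen; one five-membered non-aromatic ring of carbon only, one five-membered non-aromatic ring with 1 hetero atom) in place of a group of 6 heavy atoms (5 carbon, 1 nitrogen; one six-membered non-aromatic ring with 1 hetero atom), on an aromatic carbon. The entering group keeps a single ring nitrogen as its only hydrogen-bond acceptor and is close in size to the group it replaces. Going by the values given here, the one step that bears on this change, from compound 1 to compound 2, was within the scatter, which suggests that this position tolerates variation of the amine without a large shift in this assay.

Compound 3 is therefore expected to land close to compound 2, with an estimated step of a 1.2-fold higher number from compound 2 to compound 3 (0.07 log units; within the scatter). The estimate for compound 3 in this assay is 130 nM, with a range from 45 nM to 400 nM.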

Compound 3, half-maximal effective concentration: 150 nM
Compound 3: middle estimate off by 1.2-fold (0.06 log units), on the low side; the measured number falls inside the stated range.
By their numbers in this assay, from the lowest: compounds 2, 1 and 3 (each within the scatter of the next).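

Placing the bridged amine of compound 3 on this aromatic carbon instead of piperidin-1-yl gives a 1.4-fold higher number from compound 2 to compound 3 (0.13 log units; within the scatter) in this assay on the shared core. Placing it there instead of the open-chain isopropyl(methyl)amino gives a 1.1-fold higher number from compound 1 to compound 3 (0.03 log units; within the scatter) in the same assay. The earlier pair had shown this tolerance only for an open-chain amine and a piperidine, whereas these steps extend it to a bridged group, so the open-chain, piperidin-1-yl and bridged amines cannot be told apart on this read-out, and no further data at hand speak to why they agree.

The compounds shown leave open whether this place stays as undemanding when the amine is replaced by a different kind of group, such as morpholin-4-yl with its ring oxygen, a methylamino group carrying an amine hydrogen, or a carboxylic acid. They also leave open whether the same tolerance holds when the trifluoromethyl group or the amide chain, which are the same in all three compounds, is changed together with the amine.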